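This account rests on a few compounds, and the source may have more. Where it says the series, first, only, none or still open, it means among the compounds named here.

Measured so far in a functional assay on SEM cells (Homo sapiens) for cytotoxicity, with a stated time of 72 h; on this read-out higher numbers stand for an effect only at larger amounts of compound and lower numbers for an effect already at smaller amounts:
- compound 1, `C=C[C@@](C)(/C=C/c1ccc(Nc2ccc(F)c(F)c2)cc1)CCC=C(C)C`: > 36600 nM, a limit of the assay rather than a number
- compound 2, `C=C[C@@](C)(/C=C/c1ccc(Nc2cc(F)cc(F)c2)cc1)CCC=C(C)C`: > 36600 nM, again only a limit
- compound 3, `C=C[C@@](C)(/C=C/c1ccc(Nc2ccc(Cl)c(Cl)c2)cc1)CCC=C(C)C`: > 36600 nM, again only a limit

Compound 3 therefore does not stand at a measured number at all; it sits at the limit of > 36600 nM in this assay, at which 3 of the 3 values shown sit, together with the other two compounds. The three steps among them, a step that the two limits leave unreadable from compound 1 to compound 2, a step that the two limits leave unreadable from compound 1 to compound 3 and a step that the two limits leave unreadable from compound 2 to compound 3, cannot be read: none tells whether changing the halogen pattern on the ring attached to the nitrogen moved the result at all.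

The next compound, compound 4 `C=C[C@@](C)(/C=C/c1ccc(-c2cccc(Br)c2)cc1)CCC=C(C)C`, differs from compound 3 in another way: 3-bromophenyl in place of (3,4-dichlorophenyl)amino on an aromatic carbon. Here the nitrogen itself leaves, and the new ring attaches directly to the aromatic carbon. None of the three measured steps touches this kind of change, and all of them are unreadable anyway, so no size or direction of step can be derived from them. The most that can be expected is that compound 4 behaves like the compounds already seen, most probably again reaching only the limit of this assay. On that basis compound 4 is expected to give about 40000 nM, within 12000 nM to 120000 nM. The step that the limit leaves unreadable from compound 3 to compound 4 that this estimate implies is expected to be small, not beyond the scatter.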

Compound 4, half-maximal effective concentration: > 36600 nM
Compound 4 gave a limit, no number; the forecaster's own chance of this, stated with the estimate: 70%; the middle value does not contradict the limit.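

In this assay compound 4 gives > 36600 nM as a limit and not a number. Its steps from compound 1, compound 2 and compound 3 therefore cannot be read, and all values shown share one position: the limit of > 36600 nM in this assay, at which 4 of the 4 values shown sit. The compounds shown leave open whether any of these changes alters the result, and at what concentration any of them would show an effect.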